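The source may hold more compounds than are shown below. What is called first, only, known or untested is meant among the compounds shown, and "the series" means these compounds.

Measured compounds:
- compound 1 `COc1ccc(C(=O)Nc2nccn3cc(-c4ccccc4)nc23)cc1`: 1%
- compound 2 `COc1ccc(C(=O)Nc2nc(-c3ccccc3)cn3cc(-c4ccccc4)nc23)cc1`: 6%
- compound 3 `O=C(c1ccc(F)cc1)N(C(=O)c1ccc(F)cc1)c1nc(-c2ccccc2)cn2cc(-c3ccccc3)nc12`: 1%

In an assay on cells for displacement of a labelled ligand from adenosine receptor A1 (Homo sapiens), read by scintillation counting, with a stated time of 120 min, tested at 1 uM (on this read-out higher numbers stand for more inhibition at the one concentration tested (going by the name of the read-out) and lower numbers for less inhibition), compound 2 gives 6%, which is the largest of the three numbers, yet its gap to compound 1 and its gap to compound 3 both lie within the usual scatter, so none of the three can be told apart. Among the compounds with values here, the one step that connects two of the measured compounds is a number 5 percentage points higher from compound 1 to compound 2 (within the scatter), a change at an aromatic carbon that leaves the number where it was. Compound 3 and compound 2 are not joined by a step of one difference; their values, in this assay, simply show that both sit near the bottom of the range.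

Compound 4 `O=C(Nc1nc(-c2ccccc2)cn2cc(-c3ccccc3)nc12)c1ccco1` differs from compound 2 by furan-2-yl in place of 4-methoxyphenyl on a carbonyl carbon. Within the data shown here, no measured step touches the group on the carbonyl carbon, so nothing among the measured compounds bears directly on this change. What the data do show is that every change seen so far left the read-out in this assay low and within the scatter. Compound 4 is therefore expected to give a step of a number 1 percentage points lower from compound 2 to compound 4 (within the scatter), that is, no movement beyond the scatter. The estimate for compound 4 in this assay is 5%, with a range from 0% to 15%.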

Compound 4, a percentage reported as inhibition, at one concentration (the size of the read-out at that concentration, not a potency): 10%
The estimate for compound 4 lay 5 percentage points below the measured number; the range from low to high includes it.
By their numbers in this assay, from the lowest: compounds 1, 3, 2 and 4 (each within the scatter of the next).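

In this assay, within the data shown here, the group on the carbonyl carbon is varied for the first time: furan-2-yl in place of 4-methoxyphenyl gives a number 4 percentage points higher from compound 2 to compound 4 (within the scatter) and thus adds a second step that stays inside the scatter. This shows that, on the amide-type nitrogen side of the shared core, the aromatic ring on the carbonyl carbon can go from a six-membered ring of carbon only, with 8 heavy atoms, to a five-membered ring with 1 hetero atom, with 5 heavy atoms, without the read-out moving measurably. Nothing measured on these compounds offers an explanation for this lack of movement.

The compounds shown leave open whether a group that is not an aromatic ring, such as a piperidine, a longer alkyl chain or a chain ending in a carboxylic acid, would move the number beyond the scatter when placed on the carbonyl carbon. They also leave open whether an amine on this carbonyl carbon would do so with the two phenyl groups of compound 2 kept in place.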